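The compounds below may be only part of what the source reports. "The series", "measured", "known", "first", "only" and "open" are said of these compounds alone.

In a functional assay on HeLa cells (Homo sapiens) for antiproliferative activity, read by MTT assay, with a stated time of 72 h (on this read-out higher numbers stand for weaker inhibition and lower numbers for stronger inhibition), compound 2 `CCn1cc(C(=O)O)c(=O)c2cc(F)c(N3CCN(C(=N)NS(=O)(=O)c4ccccc4Cl)CC3)cc21` gives 32 nM, level with compound 1 `CCn1cc(C(=O)O)c(=O)c2cc(F)c(N3CCN(C(=N)NS(=O)(=O)c4cccc(Cl)c4)CC3)cc21` at 32 nM and compound 3 `N=C(NS(=O)(=O)c1ccccc1Cl)N1CCN(c2cc3c(cc2F)c(=O)c(C(=O)O)cn3C2CC2)CC1` at 32 nM. Compound 4 `CCn1cc(C(=O)O)c(=O)c2cc(F)c(N3CCN(C(=N)NS(=O)(=O)c4ccc(C)cc4)CC3)cc21` has 4-methylphenyl in place of 2-chlorophenyl on a sulfonyl sulfur. Within the data shown here, two measured steps bear on this. The only one at the same place is no change at the digits printed from compound 1 to compound 2 (within the scatter), and the other is no change at the digits printed from compound 2 to compound 3 (within the scatter). Going by these compounds, both stay within the scatter, but only chlorophenyl groups have been measured at this place, so 4-methylphenyl is untested there. Resting on no change at the digits printed from compound 1 to compound 2 (within the scatter), no shift beyond the scatter is expected in this assay, in either direction. The estimated no change at the digits printed from compound 2 to compound 4 (within the scatter) is therefore small. For compound 4 the expected value is 32 nM, within an estimated range of 13 nM to 85 nM.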

Compound 4, half-maximal inhibitory concentration: 32 nM
Compound 4: the middle estimate sits on the measured number at the digits printed; low and high end bracket the measured number.
By their numbers in this assay, from the lowest: compounds 1, 2, 3 and 4 (each within the scatter of the next).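

In this assay the read-out holds, with no change at the digits printed from compound 2 to compound 4 (within the scatter) and no change at the digits printed from compound 1 to compound 4 (within the scatter) when 4-methylphenyl stands on the sulfonyl sulfur. The level result at this place therefore no longer rests on chlorophenyl groups alone, since a group of carbon only sits with 2-chlorophenyl and 3-chlorophenyl. Nothing available explains this level result. Open, going by these compounds, is whether a non-aromatic group on the sulfonyl sulfur, such as cyclohexyl or methyl, or a phenyl ring carrying an amine or a carboxylic acid, stays at the same level.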